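Triazole carbon methyl to trifluoromethyl: an untested direction

The source may hold more compounds than are shown below. What is called first, only, known or untested is meant among the compounds shown, and "the series" means these compounds.

The series shares one core, seen in compound 1 `Cc1c(C(=O)Nc2ccc(Oc3ccnc4[nH]ccc34)cc2)nnn1-c1ccc(F)cc1`, which in a functional assay on HT-29 cells (Homo sapiens) for cytotoxicity, read by MTT assay, with a stated time of 72 h (on this read-out lower numbers stand for stronger inhibition and higher numbers for weaker inhibition), gives 180 nM. Compound 2 `Cc1c(C(=O)Nc2ccc(Oc3ccnc4[nH]ccc34)cc2)nnn1-c1ccc(F)c(F)c1` gives 1070 nM, and compound 3 `Cc1c(C(=O)Nc2ccc(Oc3ccnc4[nH]ccc34)cc2)nnn1-c1ccc(Cl)c(C(F)(F)F)c1` gives 3290 nM. The measured steps all change the group on the aromatic nitrogen: a 5.9-fold higher number from compound 1 to compound 2 (0.77 log units; beyond the scatter), an 18-fold higher number from compound 1 to compound 3 (1.26 log units; beyond the scatter) and a 3.1-fold higher number from compound 2 to compound 3 (0.49 log units; beyond the scatter). Compound 3 therefore stands with the highest number of the three, beyond the scatter from both compound 2 and compound 1.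

Compound 4 `O=C(Nc1ccc(Oc2ccnc3[nH]ccc23)cc1)c1nnn(-c2ccc(Cl)c(C(F)(F)F)c2)c1C(F)(F)F` keeps the 4-chloro-3-(trifluoromethyl)phenyl group of compound 3 and differs only in trifluoromethyl in place of methyl on an aromatic carbon. Among the measured compounds shown here, none of the measured steps touches this carbon of the five-membered aromatic ring with 3 nitrogen; every step so far concerns the group on the aromatic nitrogen, so there is no direct precedent for the size or direction of this change. The only indirect hint is that each enlargement within this set has so far given a higher number, as in the step from compound 1 to compound 3, but that is a different place on the molecule.

Compound 4 is therefore expected to show a 1.5-fold higher number from compound 3 to compound 4 (0.18 log units; within the scatter). For compound 4 the estimate in this assay is 5000 nM, with a range from 1500 nM to 16000 nM.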

Compound 4, half-maximal inhibitory concentration: 1530 nM
Compound 4: middle estimate off by 3.3-fold (0.51 log units), on the high side; the range from low to high includes it.
By their numbers in this assay, from the lowest: compound 1; then compounds 2 and 4 (each within the scatter of the next); then compound 3.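

Trifluoromethyl in place of methyl on the aromatic carbon of the five-membered ring, with the 4-chloro-3-(trifluoromethyl)phenyl group held fixed, gives a 2.2-fold lower number from compound 3 to compound 4 (0.33 log units; beyond the scatter) in this assay, so the read-out responds at this carbon as well as on the aromatic nitrogen. The earlier steps shown here, all on the aromatic nitrogen, each ran to a higher number as the group there grew, whereas here 4 heavy atoms entering for 1 heavy atom run to a lower number, so compound 4 goes against any reading in which a larger group always gives a higher number. Nothing available on these compounds accounts for this step.

As far as these compounds go, the step is read only with the 4-chloro-3-(trifluoromethyl)phenyl group on the aromatic nitrogen, so whether it holds with the 4-fluorophenyl group of compound 1 remains open. Also open, from the compounds shown here alone, is how this carbon responds to other groups, such as hydrogen, ethyl, a nitrile or an amine, and whether the lower number persists with any of them.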